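Two Basic Side Chains Replace a Pyridinylmethyl Arm

A few compounds are considered here, and "the series" means these few. Any claim that something is new, unique, unknown or untested is made for them only; others in the source may bear on it.

Measured compounds in an assay on HEK293 cells for inhibition of Steryl-sulfatase (Homo sapiens), tested at 0.1 uM; a higher number here means a stronger effect of the compound at the concentration tested, a lower number a weaker effect:
- compound 1, `NS(=O)(=O)Oc1ccc2c(c1)CN(C(=O)c1cccc(N3CCN(c4ncccn4)CC3)c1)CC2`, gives 1.6%
- compound 2, `CN(C)CCCN(Cc1ccccc1)c1cccc(C(=O)N2CCc3ccc(OS(N)(=O)=O)cc3C2)c1`, gives 23.8%
- compound 3, `CCN(Cc1ccncc1)c1cccc(C(=O)N2CCc3ccc(OS(N)(=O)=O)cc3C2)c1`, gives 33.3%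

Compound 3 shows the largest number of the three, but its gap to compound 2 is within the scatter, so the two cannot be ranked; only compound 1 lies clearly below.

Compound 4, `CN(C)CCN(CCN(C)C)c1cccc(C(=O)N2CCc3ccc(OS(N)(=O)=O)cc3C2)c1`, has not yet been measured. It differs from compound 3 in one place: bis(2-(dimethylamino)ethyl)amino in place of ethyl((pyridin-4-yl)methyl)amino on an aromatic carbon. Compound 2, which also carries a dimethylamino-bearing chain at that position, sits close to compound 3, so no step beyond the scatter is expected; the estimated step from compound 3 to compound 4 is a number 7.3 percentage points lower from compound 3 to compound 4 (within the scatter). Compound 4 is therefore expected to give about 26% in this assay, between 8% and 45%.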

Compound 4, a percentage reported as inhibition, at one concentration (the size of the read-out at that concentration, not a potency): 0%
Compound 4: middle estimate off by 26 percentage points, on the high side; the measured number lies below the stated range.
By their numbers in this assay, from the lowest: compounds 4 and 1 (each within the scatter of the next); then compounds 2 and 3 (each within the scatter of the next).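

In this assay, the group on this aromatic carbon clearly matters: bis(2-(dimethylamino)ethyl)amino in place of ethyl((pyridin-4-yl)methyl)amino gives a number 33.3 percentage points lower from compound 3 to compound 4 (beyond the scatter). The two groups are close in heavy-atom count, but the entering one has no ring and carries more nitrogen. Nothing measured here gives a cause for this loss. The compounds shown leave open whether losing the pyridine ring or gaining two dimethylamino chains matters more. An ethyl(2-(dimethylamino)ethyl)amino group, which has one such chain and no ring, would help separate the two.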